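Notes on compound 4: chloro to methyl on the pyridinyl ring

The compounds below may be only part of what the source reports. "The series", "measured", "known", "first", "only" and "open" are said of these compounds alone.

Of the compounds shown here, three have been measured in an in vitro assay on HEK385-7 cells for displacement of a labelled ligand from prostaglandin D2 receptor 2 (Homo sapiens); on this read-out lower numbers stand for stronger inhibition and higher numbers for weaker inhibition. Compound 1 `O=C(O)Cc1sc(C(c2ccc(F)cc2)c2ccc(F)cc2)nc1-c1ccc(Cl)cc1` gives 9.7 nM, compound 2 `O=C(O)Cc1sc(C(c2ccc(F)cc2)c2ccc(F)cc2)nc1-c1ccccc1` gives 16 nM, and compound 3 `O=C(O)Cc1sc(C(c2ccc(F)cc2)c2ccc(F)cc2)nc1-c1ccnc(Cl)c1` gives 3.1 nM. Compound 3 holds the lowest number of the three: the step of a 3.1-fold lower number from compound 1 to compound 3 (0.50 log units; beyond the scatter) and the step of a 5.2-fold lower number from compound 2 to compound 3 (0.71 log units; beyond the scatter) both lie beyond the scatter, so compound 3 is the strongest binder measured so far. The step of a 1.6-fold higher number from compound 1 to compound 2 (0.22 log units; within the scatter), by contrast, is within the scatter.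

Compound 4 `Cc1cc(-c2nc(C(c3ccc(F)cc3)c3ccc(F)cc3)sc2CC(=O)O)ccn1` differs from compound 3 by methyl in place of chloro on an aromatic carbon. Within the data shown here, no measured step exchanges chloro for methyl, and none alters a substituent on the 2-chloropyridin-4-yl group. Among the measured compounds shown here, the only measured step that touches a chloro at all, a 1.6-fold higher number from compound 1 to compound 2 (0.22 log units; within the scatter), sits on the other aryl ring and is within the scatter. Because a 1.6-fold higher number from compound 1 to compound 2 (0.22 log units; within the scatter) shows so little movement on removing a chloro, swapping chloro for methyl is expected to change the number by no more than the scatter, if at all, with a slight lean toward a higher number.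

Compound 4 is therefore expected to show a step of a 1.5-fold higher number from compound 3 to compound 4 (0.16 log units; within the scatter). In this assay compound 4 is estimated at 4.5 nM, with a range from 2 nM to 10 nM.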

Compound 4, half-maximal inhibitory concentration: 3.1 nM
Compound 4: the middle estimate sits 1.5-fold (0.16 log units) above what was measured, and the stated range covers the measured number.
By their numbers in this assay, from the lowest: compounds 3 and 4 (each within the scatter of the next); then compounds 1 and 2 (each within the scatter of the next).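

In this assay, among these compounds, the step of no change at the digits printed from compound 3 to compound 4 (within the scatter) gives the first direct reading of a substituent on this pyridinyl ring, and at this position, next to the ring nitrogen, methyl and chloro cannot be told apart. The gain over the other aryl groups also survives the exchange: the 2-methylpyridin-4-yl group gives a 5.2-fold lower number from compound 2 to compound 4 (0.71 log units; beyond the scatter) and a 3.1-fold lower number from compound 1 to compound 4 (0.50 log units; beyond the scatter), both beyond the scatter, so among the two pyridinyl compounds that gain does not depend on the chloro. Nothing available explains why the two substituents read alike.

The compounds shown leave open whether this position needs a substituent at all, since what a plain pyridin-4-yl group would give is unknown, as is the outcome with a larger or heteroatom-bearing group there, such as a methoxy group, an amine or a trifluoromethyl group. From the compounds shown here alone, it also stays open how much of the gain rests on the ring nitrogen itself, a question that a 3-methylphenyl group in place of the 2-methylpyridin-4-yl group would address directly.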